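The source may report more compounds than this note shows. Statements on the series, on what has been measured and on what is new or still open speak of the compounds shown alone.

In a functional assay on MCF7 cells (Homo sapiens) for cytotoxicity, read by MTT assay, with a stated time of 48 h (a higher number here means a weaker inhibitor, a lower number a stronger inhibitor), three compounds have been measured so far. Compound 3 (`COc1ccc(-c2nnc(COc3ccc(C#N)c(F)c3)o2)cc1`) gives 42200 nM. Compound 1 (`COc1cc(C#N)ccc1OCc1nnc(-c2ccc(C)cc2)o1`) gives 27100 nM, which lies within the scatter of the number for compound 3. Compound 2 (`COc1cc(C#N)ccc1OCc1nnc(-c2ccc(F)cc2)o1`) gives 10300 nM, and the number for compound 3 stands higher than this by a margin beyond the scatter.

The next compound is compound 4 (`N#Cc1ccc(OCc2nnc(-c3ccc(F)cc3)o2)cc1F`), which departs from compound 3 in one place: fluoro in place of methoxy on an aromatic carbon. This is fluoro in place of methoxy on an aromatic carbon, so 4-methoxyphenyl becomes 4-fluorophenyl.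

Going by the values given here, only one measured step comes close to this change: a 2.6-fold lower number from compound 1 to compound 2 (0.42 log units; beyond the scatter), with fluoro in place of methyl on an aromatic carbon. That step was modest but beyond the scatter. Among the compounds with values here, it is an imperfect guide, as no measured pair has methoxy as the group that leaves, and compound 1 and compound 2 also differ from compound 3 elsewhere in the structure. A modest move toward a lower number in this assay is therefore expected, of about the same size as that one step. The expected step is a 2.6-fold lower number from compound 3 to compound 4 (0.42 log units; beyond the scatter). Compound 4 is estimated at 16000 nM, with an expected range from 6000 nM to 40000 nM.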

Compound 4, half-maximal inhibitory concentration: 20500 nM
Beside the measured number, compound 4's estimate is 1.3-fold (0.11 log units) below it; measured number inside the range.
By their numbers in this assay, from the lowest: compounds 2, 4, 1 and 3 (each within the scatter of the next, the first and the last beyond it).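

In this assay, going by these compounds alone, the exchange of methoxy for fluoro on the aromatic carbon para to a large group gives a 2.1-fold lower number from compound 3 to compound 4 (0.31 log units; beyond the scatter) and so shows that the place also answers when methoxy is the group that leaves, which no earlier pair could show. Within the data shown here, the only earlier change at this place was a methyl leaving, with a 2.6-fold lower number from compound 1 to compound 2 (0.42 log units; beyond the scatter) as its step, so two pairs with different remainders now both move toward a lower number by a modest step beyond the scatter, and neither goes against this, though it extends no further than these four compounds. No measurement shown here accounts for the step, so it stands as an observation without an explanation.

What remains open is whether fluoro itself matters at this place, since hydrogen, chloro, a hydroxyl, an amine or a longer chain such as ethoxy do not appear there among these compounds. Also open, from the compounds shown here alone, is whether the step from methoxy to fluoro would hold with the nitrile-bearing end of compound 1 in place of that of compound 3.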